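Ester variation at the carbonyl of compound 3

This account rests on a few compounds, and the source may have more. Where it says the series, first, only, none or still open, it means among the compounds named here.

Compound 3 `Cc1cccc(OC(=O)C2=C(c3ccc(Cl)c(Cl)c3)CCC2)c1` gives the lowest number of the three measured compounds in an assay on COS-1 cells for displacement of a labelled ligand from sodium-dependent dopamine transporter (Homo sapiens) (a higher number here means a weaker inhibitor, a lower number a stronger inhibitor), namely 60 nM. Compound 2 `CON(C)C(=O)C1=C(c2ccc(Cl)c(Cl)c2)CCC1` gives 6400 nM in this assay, and compound 1 `O=C(C1=C(c2ccc(Cl)c(Cl)c2)CCC1)N1CCCC1` gives 58000 nM. Among the compounds with values here, the only step between measured compounds that differ in one place, a 9.1-fold lower number from compound 1 to compound 2 (0.96 log units; beyond the scatter), concerns the group on the amide nitrogen and leaves the ester oxygen untouched, so it offers no direct guide for the next change. Compound 4 `O=C(OCc1cccs1)C1=C(c2ccc(Cl)c(Cl)c2)CCC1` differs from compound 3 by (thiophen-2-yl)methyl in place of 3-methylphenyl on an oxygen next to a carbonyl group. Within the data shown here, no measured pair varies the group on this oxygen; both compounds keep the carbonyl and the shared core, and the two ester groups are of similar size. Nothing measured here points in either direction, so the step is expected to stay small relative to the spread of the series, with a slightly higher number allowed for as the more likely side; the expected step is a 2.5-fold higher number from compound 3 to compound 4 (0.40 log units; beyond the scatter). Compound 4 is therefore estimated at 150 nM in this assay, with a range from 40 nM to 600 nM.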

Compound 4, inhibition constant: 400 nM
Compound 4: the middle estimate sits 2.7-fold (0.43 log units) below what was measured, within the range that was stated.
By their numbers in this assay, from the lowest: compound 3; then compound 4; then compound 2; then compound 1.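

In this assay, within the data shown here, the first measured change to the group on an oxygen next to a carbonyl group, (thiophen-2-yl)methyl in place of 3-methylphenyl, gives a 6.7-fold higher number from compound 3 to compound 4 (0.82 log units; beyond the scatter), so the number at this position responds to the ester group even though the two groups differ little in heavy-atom count. Compound 4 also shows that a second ester group can keep the number well under those of the two amides, with a 16-fold lower number from compound 2 to compound 4 (1.20 log units; beyond the scatter) and a 150-fold lower number from compound 1 to compound 4 (2.16 log units; beyond the scatter), although the size of this gain depends on which amide is the starting point. No measurement is available that explains either the difference between the two esters or the difference between the esters and the amides.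

The step from compound 3 to compound 4 swaps the six-membered aromatic ring for the five-membered one and also changes how the ring is attached to the oxygen, so the compounds shown leave open which of the two changes accounts for the higher number. A benzyl group or a directly attached thiophen-2-yl group on this oxygen would separate the two, and a 2-phenylethyl group would show how the number follows a longer chain.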